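A few compounds are considered here, and "the series" means these few. Any claim that something is new, unique, unknown or untested is made for them only; others in the source may bear on it.

In a functional assay on cells (T-cell line, Homo sapiens) for inhibition (on this read-out lower numbers stand for stronger inhibition and higher numbers for weaker inhibition), compound 1 `Cc1ccc(CCCN2CCC(COC(c3ccccc3)c3ccccc3)CC2)cc1` gives 200 nM, and compound 2 `COc1ccccc1CCCN1CCC(COC(c2ccccc2)c2ccccc2)CC1` gives 2400 nM, the higher of the two numbers. Compound 3 `Clc1ccc(CCCN2CCC(COC(c3ccccc3)c3ccccc3)CC2)cc1Cl` carries 3,4-dichlorophenyl in place of 2-methoxyphenyl, on a saturated chain carbon, three bonds along the chain from an amine nitrogen in a ring: 3,4-dichlorophenyl in place of 2-methoxyphenyl on a saturated chain carbon, three bonds along the chain from an amine nitrogen in a ring. For the measured compounds named here, only one measured step bears on this change, the large 12-fold higher number from compound 1 to compound 2 (1.08 log units; beyond the scatter), which arrived with 2-methoxyphenyl at that same place. With that group gone, a large drop in the number is expected, a 6.9-fold lower number from compound 2 to compound 3 (0.84 log units; beyond the scatter). For compound 3 the estimated value is 350 nM, with an expected range of 90 nM to 1300 nM.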

Compound 3, half-maximal inhibitory concentration: 2200 nM
Beside the measured number, compound 3's estimate is 6.3-fold (0.80 log units) below it; measured number above the stated range.
By their numbers in this assay, from the lowest: compound 1; then compounds 3 and 2 (each within the scatter of the next).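

In this assay, 3,4-dichlorophenyl in place of 2-methoxyphenyl gives a 1.1-fold lower number from compound 2 to compound 3 (0.04 log units; within the scatter), so at this place the higher number is not confined to 2-methoxyphenyl. 3,4-dichlorophenyl in place of 4-methylphenyl gives an 11-fold higher number from compound 1 to compound 3 (1.04 log units; beyond the scatter), leaving compound 1 alone with the lower number among these three. No measurement here accounts for this result. Still open, going by these compounds, is whether the lower number of compound 1 depends on its methyl group, and how phenyl or 4-chlorophenyl would read at this place.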